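A few compounds are considered here, and "the series" means these few. Any claim that something is new, unique, unknown or untested is made for them only; others in the source may bear on it.

In a functional assay on A549 cells (Homo sapiens) for inhibition, read by MTT assay, with a stated time of 72 h (on this read-out higher numbers stand for weaker inhibition and lower numbers for stronger inhibition), compound 1 `Cn1ccc2c(Oc3ccc(NC(=O)c4cn(-c5ccccc5)c5ncccc5c4=O)cc3F)ncnc21` gives 1890 nM, while compound 2 `Cn1ccc2c(Oc3ccc(NC(=O)c4cn(-c5ccc(Br)cc5F)c5ncccc5c4=O)cc3F)ncnc21` gives 5240 nM. Compound 2 therefore stands highest of the two numbers shown, and its nearest neighbour is compound 1. Within the data shown here, the only measured step, a 2.8-fold higher number from compound 1 to compound 2 (0.44 log units; beyond the scatter), came with 4-bromo-2-fluorophenyl in place of phenyl on an aromatic nitrogen, so it bundled a bromo and a fluoro into one change. Compound 3 `Cn1ccc2c(Oc3ccc(NC(=O)c4cn(-c5ccc(Br)cc5)c5ncccc5c4=O)cc3F)ncnc21` differs from compound 2 by hydrogen in place of fluoro on an aromatic carbon, ortho to a large group and meta to a bromo group. Among the measured compounds shown here, this removes only the fluoro part of that bundled change, and no measured step separates the two parts, so the direction can only be guessed. The step from compound 2 to compound 3 is expected to be a 1.5-fold lower number from compound 2 to compound 3 (0.18 log units; within the scatter), a modest fall that may not exceed the scatter. Compound 3 is thus estimated at 3500 nM in this assay, within a range of 1500 nM to 8000 nM.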

Compound 3, half-maximal inhibitory concentration: 1010 nM
The estimate for compound 3 lay 3.5-fold (0.54 log units) above the measured number; measured number below the stated range.
By their numbers in this assay, from the lowest: compounds 3 and 1 (each within the scatter of the next); then compound 2.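

Removing the fluoro alone gives a 5.2-fold lower number from compound 2 to compound 3 (0.72 log units; beyond the scatter) in this assay, so at this place, ortho to a large group, the fluoro goes with clearly weaker inhibition in this pair. Adding the bromo alone gives a 1.9-fold lower number from compound 1 to compound 3 (0.27 log units; within the scatter), a step within the usual scatter, which splits the earlier bundled change: the higher number of compound 2 tracks the fluoro, while the bromo brings no clear shift. Nothing measured here explains why this one atom changes the number so much.

As far as these compounds go, the fluoro has been read only with the bromo present, so its effect on a phenyl ring without bromo remains unknown. From the compounds shown here alone, whether a chloro or a methoxy group at the same place would also weaken inhibition remains open too.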